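A benzyloxy pyrazole amide and its reversed-amide partner

The source may hold more compounds than are shown below. What is called first, only, known or untested is meant among the compounds shown, and "the series" means these compounds.

Compound 1, `Cc1cc(C(=O)Nc2ccccn2)nn1Cc1cc(Cl)ccc1OCc1ccccc1`, in a physicochemical assay for lipophilicity, at pH 7.4; a higher number here means a more lipophilic compound, a lower number a more polar compound: > 3.7
Compound 2, `Cc1cc(C(=O)NN2CCCCC2)nn1Cc1cc(Cl)ccc1OCC(C)C`, in this assay: 3.3
Compound 3, `Cc1cc(C(=O)NN2CCOCC2)nn1Cc1cc(Cl)ccc1OCC(C)C`, in this assay: 3.1

In this assay compound 1 reaches only a limit of the assay, > 3.7, so no number is known for it; it is the limit of > 3.7 in this assay, at which 1 of the 3 values shown sits. Among the measured compounds shown here, compound 2 and compound 3 both carry numbers, and the one step measured between them, a number 0.20 log units lower from compound 2 to compound 3 (within the scatter), is small. Compound 4, `Cc1cc(NC(=O)C2CCCO2)nn1Cc1cc(Cl)ccc1OCc1ccccc1`, has not yet been measured in this assay. It differs from compound 1 in one place: ((oxolan-2-yl)carbonyl)amino in place of (pyridin-2-yl)carbamoyl on an aromatic carbon. For the measured compounds named here, the only measured step, a number 0.20 log units lower from compound 2 to compound 3 (within the scatter), concerns the amide-type nitrogen of compounds 2 and 3, not the aromatic carbon where compound 4 differs, and so gives little guidance; no measured pair mirrors the exchange of an aromatic six-membered ring for a saturated five-membered one. Since compound 1 sits at a limit, the step can only be estimated from its edge. Compound 4 is expected to come out near 3.3, between 2.8 and 3.9, which would be an estimated step of a number at least 0.40 log units lower from compound 1 to compound 4 (beyond the scatter).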

Compound 4, distribution coefficient: > 3.7
Compound 4: no number, only a limit (the forecaster's own chance of this, stated with the estimate: 20%); middle value at least 0.40 log units from the limit.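

In this assay compound 4 gives > 3.7, a limit and not a number. Compound 1 sits at the same limit, so no step can be read from compound 1 to compound 4: the limit of > 3.7 in this assay, at which 2 of the 4 values shown sit.

The compounds shown leave open whether compound 1 and compound 4 differ at all in this assay, and by how much.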